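This account rests on a few compounds, and the source may have more. Where it says the series, first, only, none or still open, it means among the compounds named here.

Compound 1 (`Nc1nc(-c2ccc(Cl)cc2)cc(-c2ccc(OCc3cn(Cc4ccccc4)nn3)cc2O)n1`) reads 66600 nM in an ADME assay on cells (Macrophage) for cytotoxicity, read by resazurin assay, with a stated time of 48 h (on this read-out lower numbers stand for higher toxicity in this test and higher numbers for lower toxicity in this test), and compound 2 (`COc1ccc(-c2cc(-c3ccc(OCc4cn(Cc5ccccc5)nn4)cc3O)nc(N)n2)cc1`) reads 42700 nM on the same test, so the two stand level. Compound 3 (`Nc1nc(-c2ccc(OCc3cn(Cc4ccccc4)nn3)cc2O)cc(-c2cccc3ccccc23)n1`) has naphthalen-1-yl in place of 4-methoxyphenyl on an aromatic carbon. Going by the values given here, no measured step replaces this whole group. Among the compounds with values here, the one step available (a 1.6-fold lower number from compound 1 to compound 2 (0.19 log units; within the scatter)) swapped only chloro for methoxy on an aromatic carbon, so it is a weak guide, and no step beyond the scatter is expected. The expected step is small (a 1.2-fold lower number from compound 2 to compound 3 (0.07 log units; within the scatter)). Compound 3 is estimated at 36000 nM (range 14000 nM to 85000 nM).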

Compound 3, half-maximal cytotoxic concentration: 71300 nM
Estimate against measurement, compound 3: 2.0-fold (0.30 log units) below; measured number inside the range.
By their numbers in this assay, from the lowest: compounds 2, 1 and 3 (each within the scatter of the next).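

At this position, naphthalen-1-yl, with 2 aromatic rings and no oxygen, gives a reading in this assay that stays within the scatter of both 4-methoxyphenyl (a 1.7-fold higher number from compound 2 to compound 3 (0.22 log units; within the scatter)) and 4-chlorophenyl (a 1.1-fold higher number from compound 1 to compound 3 (0.03 log units; within the scatter)). Among these three compounds, then, a second fused ring on this aromatic carbon does not separate the readings, which the earlier chloro-to-methoxy swap could not show. No measured evidence explains this result. Still open, from the compounds shown here alone, is whether an aromatic ring carrying an amine or a carboxylic acid here would move the reading beyond the scatter.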